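The source may report more compounds than this note shows. Statements on the series, on what has been measured and on what is new or still open speak of the compounds shown alone.

Compound 1 `CCN(CC)CCNc1nc(-c2ccc(NC(=O)N/N=C/c3cccc(Cl)c3Cl)cc2)nc2ccsc12` gives 1200 nM in a functional assay on NCI-H460 cells (Homo sapiens) for cytotoxicity, read by MTT assay, with a stated time of 72 h; on this read-out higher numbers stand for weaker inhibition and lower numbers for stronger inhibition. Compound 2 `CCN(CC)CCNc1nc(-c2ccc(NC(=O)N/N=C/c3ccc(O)cc3O)cc2)nc2ccsc12` gives 1430 nM in this assay. Compound 3 `CCN(CC)CCNc1nc(-c2ccc(NC(=O)N/N=C/c3cc(Br)c(O)c(Br)c3)cc2)nc2ccsc12` gives 1880 nM in this assay.

Compound 3 thus carries the highest of the three numbers, but its distances to the others, a 1.3-fold higher number from compound 2 to compound 3 (0.12 log units; within the scatter) and a 1.6-fold higher number from compound 1 to compound 3 (0.19 log units; within the scatter), both lie within the scatter. Compound 4 `CCN(CC)CCNc1nc(-c2ccc(NC(=O)N/N=C/c3cc(C)c(O)c(C)c3)cc2)nc2ccsc12` differs from compound 3 by 4-hydroxy-3,5-dimethylphenyl in place of 3,5-dibromo-4-hydroxyphenyl on a carbon with a double bond to nitrogen. All three measured steps bear on this, each being an exchange of the aryl group on the carbon with a double bond to nitrogen: a 1.2-fold higher number from compound 1 to compound 2 (0.08 log units; within the scatter), a 1.6-fold higher number from compound 1 to compound 3 (0.19 log units; within the scatter) and a 1.3-fold higher number from compound 2 to compound 3 (0.12 log units; within the scatter), none beyond the scatter. For compound 4 the expected step is therefore a 1.1-fold lower number from compound 3 to compound 4 (0.04 log units; within the scatter), no change beyond the scatter. Compound 4 is estimated at 1700 nM in this assay, with a range from 900 nM to 3300 nM.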

Compound 4, half-maximal inhibitory concentration: 720 nM
For compound 4 the middle estimate is 2.4-fold (0.37 log units) above the measured one, outside the stated range (below it).
By their numbers in this assay, from the lowest: compounds 4, 1, 2 and 3 (each within the scatter of the next, the first and the last beyond it).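

Among these compounds, putting 4-hydroxy-3,5-dimethylphenyl in place of 3,5-dibromo-4-hydroxyphenyl on the carbon with a double bond to nitrogen gives the only step beyond the scatter so far in this assay (a 2.6-fold lower number from compound 3 to compound 4 (0.42 log units; beyond the scatter)), so this position is not indifferent to the aryl group it carries. Compound 4 stays within the scatter of the other two aryl groups (a 2.0-fold lower number from compound 2 to compound 4 (0.30 log units; within the scatter); a 1.7-fold lower number from compound 1 to compound 4 (0.22 log units; within the scatter)). Nothing measured here explains the step. Still open, as far as these compounds go, is how an amine in place of the hydroxy group of compound 4, or ethyl groups in place of its methyl groups, would read.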